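Short half-life limits and the step to compound 4

A few compounds are considered here, and "the series" means these few. Any claim that something is new, unique, unknown or untested is made for them only; others in the source may bear on it.

In an ADME assay on microsomes from liver (Mus musculus) for metabolic stability, read by LC-MS, using NADPH, with stated times of 15 min and 60 min, tested at 4.6 uM (on this read-out lower numbers stand for a shorter-lived compound and higher numbers for a longer-lived compound), compound 1 `CN1CCN(c2ccc3c(c2)oc(=O)n3C(=O)NCCCCc2ccccc2)C(=O)C1` gives < 0.0834 h, which is a limit and not a number. Compound 3 `O=C(NCCCCc1ccccc1)n1c2c(oc1=O)CCNC2` gives < 0.25 h, also a limit. Compound 2 `CC(C)CNC(=O)n1c(=O)oc2cc(C3CCN(C)CC3)ccc21` gives > 1 h, again a limit, and it stands on the longer-lived side of the other two. All three values for the series are therefore limits, compound 1 among them.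

Compound 4 `CCN1CCC(c2ccc3c(c2)oc(=O)n3C(=O)NCCCCc2ccccc2)CC1` has 1-ethylpiperidin-4-yl in place of 4-methyl-2-oxopiperazin-1-yl on an aromatic carbon. Among the measured compounds shown here, no measured pair isolates this change. A modest rise is expected in this assay, with the estimated step of an at least 1.7-fold higher number from compound 1 to compound 4 (0.25 log units; that floor lies within the scatter). For compound 4 the estimated half-life is 0.15 h, with an expected range from 0.06 h to 0.5 h.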

Compound 4, half-life: 1 h
For compound 4 the middle estimate is 6.7-fold (0.82 log units) below the measured one; the whole stated range lies below it.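

In this assay, 1-ethylpiperidin-4-yl in place of 4-methyl-2-oxopiperazin-1-yl on an aromatic carbon gives an at least 11-fold higher number from compound 1 to compound 4 (1.07 log units; beyond the scatter). Compound 1 gives < 0.0834 h, which is a limit. This first one-place pair in the series shows that the group at this position alone can shift the half-life beyond the scatter, with the rest of compound 1 unchanged.

The change alters the ring and its nitrogen substituent together, and the compounds shown do not separate these parts. A 4-methylpiperazin-1-yl group on the same aromatic carbon would lie between the two.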